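This account rests on a few compounds, and the source may have more. Where it says the series, first, only, none or still open, it means among the compounds named here.

Values so far in a functional assay on HeLa S3 cells (Homo sapiens) for antiproliferative activity, read by XTT assay, with a stated time of 72 h (a lower number here means a stronger inhibitor, a higher number a weaker inhibitor), are as follows
compound 1 `COc1ncnc2c1c(-c1cc3ccccc3o1)cn2[C@@H]1O[C@H](CO)[C@@H](O)[C@H]1O` gives 9240 nM
compound 2 `C#Cc1cn([C@@H]2O[C@H](CO)[C@@H](O)[C@H]2O)c2ncnc(OC)c12` gives 1730 nM
compound 3 `CSc1ncnc2c1c(-c1ccoc1)cn2[C@@H]1O[C@H](CO)[C@@H](O)[C@H]1O` gives 5390 nM

Compound 3 stands second highest of the three numbers. It lies within the scatter of compound 1, while compound 2 shows a lower number, beyond the scatter.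

The next structure is compound 4 `CSc1ncnc2c1c(-c1cccs1)cn2[C@@H]1O[C@H](CO)[C@@H](O)[C@H]1O` with the change thiophen-2-yl in place of furan-3-yl on an aromatic carbon in which thiophen-2-yl stands in place of furan-3-yl on an aromatic carbon.

Among the compounds with values here, only one measured step bears on this, and only loosely. It is a 5.3-fold lower number from compound 1 to compound 2 (0.73 log units; beyond the scatter) for ethynyl in place of 1-benzofuran-2-yl on an aromatic carbon, a modest step beyond the scatter. In the present change, both the leaving and the entering group are a five-membered aromatic ring with 1 hetero atom. Within the data shown here, no measured step exchanges one such ring for another, and compound 1 and compound 2 also differ from compound 3 elsewhere on the core. No step beyond the scatter is therefore expected in this assay and no direction can be firmly assigned. The expected step is a 1.3-fold lower number from compound 3 to compound 4 (0.13 log units; within the scatter) on this estimate. For compound 4 the estimated value is 4000 nM with an expected range from 1400 nM to 11000 nM around it.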

Compound 4, half-maximal inhibitory concentration: 1960 nM
Compound 4: the middle estimate sits 2.0-fold (0.31 log units) above what was measured, and the stated range covers the measured number.
By their numbers in this assay, from the lowest: compounds 2 and 4 (each within the scatter of the next); then compounds 3 and 1 (each within the scatter of the next).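

In this assay, this aromatic carbon distinguishes between two five-membered aromatic rings with 1 hetero atom: thiophen-2-yl in place of furan-3-yl gives a 2.8-fold lower number from compound 3 to compound 4 (0.44 log units; beyond the scatter). Heavy-atom count, hydrogen-bond donor and acceptor counts and net charge are unchanged across this exchange, so the position responds to more than these computed counts. Within the data shown here, the only earlier step at this position, a 5.3-fold lower number from compound 1 to compound 2 (0.73 log units; beyond the scatter), replaced a fused 1-benzofuran-2-yl with ethynyl on a different core and could not show that an exchange between such closely matched rings also moves the number beyond the scatter; no measured evidence at hand accounts for the new step.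

Still open, from the compounds shown here alone, is whether the step follows the exchange of oxygen for sulfur or the change in ring attachment point, since the two change together here; furan-2-yl and thiophen-3-yl on the core of compound 3 would separate them. Also open, going by these compounds, is how this position on the same core responds to a group outside this ring type, such as an aminomethyl group or a carboxylic acid.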